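Second Fluorine on the Benzyl Arm: Compound 3 to Compound 4

The source may report more compounds than this note shows. Statements on the series, on what has been measured and on what is new or still open speak of the compounds shown alone.

Compound 3 `CC1(C)c2[nH]nc(NC(=O)c3ccccc3)c2CN1Cc1ccc(F)cc1` gives 1180 nM in an assay on Sf21 cells for inhibition of high affinity nerve growth factor receptor (Homo sapiens), read by HTRF, with a stated time of 30 min, in the presence of a further agent that is not named here; a lower number here means a stronger inhibitor, a higher number a weaker inhibitor. Among the three measured compounds it stands second highest, close to compound 1 `CC1(C)c2[nH]nc(NC(=O)c3ccccc3)c2CN1Cc1ccccc1` with 1240 nM and to compound 2 `CC1(C)c2[nH]nc(NC(=O)c3ccccc3)c2CN1Cc1cccc(C#N)c1` with 980 nM; all three sit within the scatter of one another, as the steps of a 1.1-fold lower number from compound 1 to compound 3 (0.02 log units; within the scatter) and a 1.2-fold higher number from compound 2 to compound 3 (0.08 log units; within the scatter) show. Compound 4 `CC1(C)c2[nH]nc(NC(=O)c3ccccc3)c2CN1Cc1cccc(F)c1F` differs from compound 3 by 2,3-difluorophenyl in place of 4-fluorophenyl on a saturated chain carbon bound to an amine nitrogen in a ring. The measured steps that bear on this each add one substituent to that ring, a 1.3-fold lower number from compound 1 to compound 2 (0.10 log units; within the scatter) and a 1.1-fold lower number from compound 1 to compound 3 (0.02 log units; within the scatter), and both stayed within the scatter. A second fluorine on the same ring is therefore expected to change little, so the step of a 1.1-fold lower number from compound 3 to compound 4 (0.03 log units; within the scatter) is expected to remain within the scatter. Compound 4 is estimated at 1100 nM, with a range from 500 nM to 2500 nM.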

Compound 4, half-maximal inhibitory concentration: 200 nM
Estimate against measurement, compound 4: 5.5-fold (0.74 log units) above, outside the stated range (below it).
By their numbers in this assay, from the lowest: compound 4; then compounds 2, 3 and 1 (each within the scatter of the next).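

Among the compounds shown here, on this saturated chain carbon, 2,3-difluorophenyl in place of the other aryl groups gives the first steps beyond the scatter: a 5.9-fold lower number from compound 3 to compound 4 (0.77 log units; beyond the scatter) and a 4.9-fold lower number from compound 2 to compound 4 (0.69 log units; beyond the scatter) and also a 6.2-fold lower number from compound 1 to compound 4 (0.79 log units; beyond the scatter). The ring is therefore not indifferent to substitution, although 4-fluorophenyl and 3-cyanophenyl stayed within the scatter of phenyl. Nothing shown here explains why this pair of fluorines matters.

On these data alone, whether the step needs both fluorines remains open. So does the effect of a chlorine, a methoxy group or an amine on this ring.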